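The compounds below may be only part of what the source reports. "The series", "measured", "known", "first", "only" and "open" are said of these compounds alone.

Compound 1 `O=C(N/N=C/c1ccc(F)cc1)Nc1ccc(Oc2ccnc3[nH]ccc23)c(F)c1` gives 800 nM in a functional assay on MCF7 cells (Homo sapiens) for antiproliferative activity, read by MTT assay, with a stated time of 72 h; on this read-out lower numbers stand for stronger inhibition and higher numbers for weaker inhibition.
Compound 2 `N#Cc1ccc(/C=N/NC(=O)Nc2ccc(Oc3ccnc4[nH]ccc34)c(F)c2)cc1` is reported in this assay as "not active" (no number reported).
Compound 3 `O=C(N/N=C/c1cccc(Cl)c1Cl)Nc1ccc(Oc2ccnc3[nH]ccc23)c(F)c1` is reported in this assay as "not active" (no number reported).

Compound 1 stands alone with a number in this assay; the two further entries carry none. Compound 4 `O=C(N/N=C/c1ccc(F)cc1Cl)Nc1ccc(Oc2ccnc3[nH]ccc23)c(F)c1` differs from compound 1 by chloro in place of hydrogen on an aromatic carbon, which, cut one bond further out, reads as 4-fluorophenyl to 2-chloro-4-fluorophenyl. For the measured compounds named here, no step between measured compounds has been recorded, so the size of this change in this assay can only be expected, not read off. Compound 3, which also carries chloro ortho to the large group, is reported as "not active" (no number reported), so a weakening beyond the scatter is expected for compound 4, amounting to a 3.1-fold higher number from compound 1 to compound 4 (0.49 log units; beyond the scatter). Compound 4 is therefore estimated at 2500 nM, within 700 nM to 9000 nM.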

Compound 4, half-maximal inhibitory concentration: 7610 nM
For compound 4 the middle estimate is 3.0-fold (0.48 log units) below the measured one; measured number inside the range.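

In this assay, for the compounds shown here, chloro in place of hydrogen on an aromatic carbon, ortho to a large group, gives a 9.5-fold higher number from compound 1 to compound 4 (0.98 log units; beyond the scatter) and is the only step here with a number at both ends. This change weakens the read-out beyond the scatter, yet compound 4 still gives a measurable number rather than an entry of "not active". Nothing measured here accounts for the loss.

From the compounds shown here alone, whether methyl, methoxy or an amine in the same place would cost as much stays open. So does whether chloro would give a similar step on a compound other than compound 1.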